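The source may report more compounds than this note shows. Statements on the series, on what has been measured and on what is new or still open speak of the compounds shown alone.

Measured compounds:
compound 1, `C=C1CC[C@@H]2[C@](C)(CO)[C@H](O)CC[C@@]2(C)[C@@H]1CC(OC(C)=O)C1=CCOC1=O`, 95.1%
compound 2, `C=C1CC[C@@H]2[C@](C)(CO)[C@H](O)CC[C@@]2(C)[C@@H]1CC(OC(=O)CC)C1=CCOC1=O`, 82.6%
compound 3, `C=C1CC[C@@H]2[C@](C)(CO)[C@H](O)CC[C@@]2(C)[C@@H]1CC(OC(=O)c1ccccc1)C1=CCOC1=O`, 82%

In a functional assay on J774.A1 cells (Mus musculus) for inhibition, read by ELISA, with a stated time of 24 h, tested at 20 uM (on this read-out higher numbers stand for more inhibition at the one concentration tested (going by the name of the read-out) and lower numbers for less inhibition), compound 3 gives the lowest of the three numbers, yet only its distance from compound 1 lies beyond the scatter: the step of a number 13.1 percentage points lower from compound 1 to compound 3 (beyond the scatter) is modest, while a number 0.6 percentage points lower from compound 2 to compound 3 (within the scatter) is within the scatter. The related step of a number 12.5 percentage points lower from compound 1 to compound 2 (beyond the scatter) is likewise modest. All three changes alter the group on the carbonyl carbon of the ester, and none touches the aromatic ring of compound 3.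

Compound 4, `C=C1CC[C@@H]2[C@](C)(CO)[C@H](O)CC[C@@]2(C)[C@@H]1CC(OC(=O)c1ccc([N+](=O)[O-])cc1)C1=CCOC1=O`, is compound 3 with a change on that ring: nitro in place of hydrogen on an aromatic carbon. Among the measured compounds shown here, no measured step bears on an addition to the aromatic ring, so the expectation rests only on the flat stretch between compound 2 and compound 3. The step expected for compound 4 is estimated as a number 4 percentage points lower from compound 3 to compound 4 (within the scatter), a small expected change that would likely stay within the scatter and, if anything, lean slightly downward. For compound 4 the estimate in this assay is 78%, with a range from 62% to 90%.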

Compound 4, a percentage reported as inhibition, at one concentration (the size of the read-out at that concentration, not a potency): 58.6%
Beside the measured number, compound 4's estimate is 19.4 percentage points above it, outside the stated range (below it).
By their numbers in this assay, from the lowest: compound 4; then compounds 3 and 2 (each within the scatter of the next); then compound 1.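

In this assay, earlier changes touched only the group on the ester carbonyl, and swapping ethyl for phenyl moved the number by no more than the scatter, but the aromatic ring now proves sensitive to substitution, with a number 23.4 percentage points lower from compound 3 to compound 4 (beyond the scatter) when nitro replaces hydrogen para to a large group. The 4-nitrophenyl ester also falls clearly short of the two smaller esters, with a number 24 percentage points lower from compound 2 to compound 4 (beyond the scatter) against ethyl and a number 36.5 percentage points lower from compound 1 to compound 4 (beyond the scatter) against methyl, and this last step is large. Nothing available explains why the number falls.

A single nitro compound cannot show whether the fall belongs to nitro itself or would follow any group placed on that ring carbon. An amine, a methoxy group or a chlorine atom at the same place would begin to separate these two readings.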